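Benzyl ring substitution and the step to compound 4

The source may hold more compounds than are shown below. What is called first, only, known or untested is meant among the compounds shown, and "the series" means these compounds.

Working notes on the series. In an assay on FRT cells for positive allosteric modulation of Cystic fibrosis transmembrane conductance regulator variant N1303K (Homo sapiens), in the presence of a further agent that is not named here (on this read-out lower numbers stand for an effect already at smaller amounts and higher numbers for an effect only at larger amounts of compound), compound 1 `COc1ccc2[nH]c3c(c2c1)CCNC31CCN(Cc2ccccc2)CC1` gives 12600 nM, compound 2 `COc1ccc2[nH]c3c(c2c1)CCNC31CCN(Cc2ccccc2Cl)CC1` gives 2200 nM and compound 3 `COc1ccc2[nH]c3c(c2c1)CCNC31CCN(Cc2ccc(F)c(Cl)c2F)CC1` gives 4500 nM. Compound 3 thus holds the second highest of the three numbers: the nearest is compound 2, reached by a 2.0-fold higher number from compound 2 to compound 3 (0.31 log units; beyond the scatter), and the furthest is compound 1, by a 2.8-fold lower number from compound 1 to compound 3 (0.45 log units; beyond the scatter).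

Compound 4 `COc1ccc2[nH]c3c(c2c1)CCNC31CCN(Cc2cc(F)cc(F)c2)CC1` differs from compound 3 as 3,5-difluorophenyl in place of 3-chloro-2,4-difluorophenyl on a saturated chain carbon bound to an amine nitrogen in a ring. All three measured steps alter the same ring. a 5.7-fold lower number from compound 1 to compound 2 (0.76 log units; beyond the scatter) goes with chloro in place of hydrogen, while a 2.8-fold lower number from compound 1 to compound 3 (0.45 log units; beyond the scatter) goes with chlorine and two fluorines entering together. Compound 4 keeps two fluorines but loses the chlorine, so a number between those of compound 1 and compound 3 is expected, nearer compound 3. The step of a 1.6-fold higher number from compound 3 to compound 4 (0.19 log units; within the scatter) is expected to stay roughly within the scatter, with the higher number the likelier side. For compound 4 the estimate in this assay is 7000 nM, with a range from 3000 nM to 16000 nM.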

Compound 4, half-maximal effective concentration: 11100 nM
The estimate for compound 4 lay 1.6-fold (0.20 log units) below the measured number; low and high end bracket the measured number.
By their numbers in this assay, from the lowest: compound 2; then compound 3; then compounds 4 and 1 (each within the scatter of the next).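

In this assay, two fluorines alone on this ring do not separate compound 4 from the plain phenyl of compound 1 (a 1.1-fold lower number from compound 1 to compound 4 (0.06 log units; within the scatter)), so halogen on the ring does not by itself account for the lower numbers seen earlier. The chlorine-bearing rings both stand apart from 3,5-difluorophenyl, with a 2.5-fold higher number from compound 3 to compound 4 (0.39 log units; beyond the scatter) for the 3-chloro-2,4-difluorophenyl comparison and a 5.0-fold higher number from compound 2 to compound 4 (0.70 log units; beyond the scatter) for the 2-chlorophenyl comparison; among these four compounds, only the two with chlorine hold the lower numbers, and no compound goes against this. The compounds shown offer no measurement that explains this difference.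

As far as these compounds go, it remains open whether chlorine itself is what matters, since compound 2 and compound 3 also differ in their fluorines and in where the chlorine sits. Also open, from the compounds shown here alone, is whether a bromine, a methyl or a nitrile on this ring would behave like chlorine.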